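This account rests on a few compounds, and the source may have more. Where it says the series, first, only, none or still open, it means among the compounds named here.

Compound 1 `COc1ccc(COc2ccc(-c3nn(CCC#N)c(=O)o3)cc2)cc1` gives 27 nM in an assay for inhibition of Amine oxidase [flavin-containing] B (Rattus norvegicus); on this read-out lower numbers stand for stronger inhibition and higher numbers for weaker inhibition. Compound 2 `Cc1cccc(COc2ccc(-c3nn(CCC#N)c(=O)o3)cc2)c1` carries 3-methylphenyl in place of 4-methoxyphenyl on a saturated chain carbon bound to an oxygen on an aromatic ring and in this assay compound 2 gives 8 nM; the step is a 3.4-fold lower number from compound 1 to compound 2 (0.53 log units; beyond the scatter). Compound 3 `COc1ccc(COc2ccc(-c3nn(CCC#N)c(=S)o3)cc2)cc1` has a different core from compound 1, and how the two cores differ is not broken down here; in this assay compound 3 gives 910 nM, the highest number of the three. Compound 4 `Cc1cccc(COc2ccc(-c3nn(CCC#N)c(=S)o3)cc2)c1` stands to compound 3 as compound 2 stands to compound 1: 3-methylphenyl in place of 4-methoxyphenyl on a saturated chain carbon bound to an oxygen on an aromatic ring, the same change at the same place, made twice among these compounds. Among the measured compounds shown here, the step to compound 4 is expected to be a 3.4-fold lower number from compound 3 to compound 4 (0.53 log units; beyond the scatter), resting on the single measured instance of this change, a 3.4-fold lower number from compound 1 to compound 2 (0.53 log units; beyond the scatter), carried over to the core of compound 3. Compound 4 is estimated at 270 nM, with an expected range from 110 nM to 650 nM.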

Compound 4, half-maximal inhibitory concentration: 66 nM
The estimate for compound 4 lay 4.1-fold (0.61 log units) above the measured number, and the stated range ends above it.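

The change from 4-methoxyphenyl to 3-methylphenyl gives a 14-fold lower number from compound 3 to compound 4 (1.14 log units; beyond the scatter) in this assay and so keeps the direction seen on the core of compound 1. The direction carries over between these two cores, but the size does not: the same change on two cores in this assay, a 3.4-fold lower number (0.53 log units; beyond the scatter) from compound 1 to compound 2 and a 14-fold lower number (1.14 log units; beyond the scatter) from compound 3 to compound 4, 4.1-fold (0.61 log units) apart, beyond the scatter of two such steps.
Among the compounds shown here, with only two pairs, this gives no rule for the size of the step on a further core and no reason for the gap.

A 4-methylphenyl or 3-methoxyphenyl group on each core would separate the identity of the substituent from its ring position. Going by these compounds, whether the larger step on the core of compound 3 extends to other groups, such as an unsubstituted phenyl or a 3-chlorophenyl, remains open.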